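A few compounds are considered here, and "the series" means these few. Any claim that something is new, unique, unknown or untested is made for them only; others in the source may bear on it.

Compound 1 `Nc1ccccc1COc1ccc(OCCOCCNC2CCCC2)cc1` — 14000 nM
Compound 2 `c1ccc(COc2ccc(OCCOCCNC3CCC3)cc2)cc1` — 25000 nM

Of the compounds shown here, two have been measured in a functional assay on SK-OV-3 cells (Homo sapiens) for inhibition, read by CCK-8 assay, with a stated time of 70 h; a lower number here means a stronger inhibitor, a higher number a weaker inhibitor. For the measured compounds named here, compound 1 gives the lowest of the two numbers, yet its only neighbour, compound 2, lies within the usual scatter of the method, so nothing separates them in this assay. Compound 3 `O=C(O)c1ccc(COc2ccc(OCCOCCNC3CCCC3)cc2)cc1` is still to be measured there. It differs from compound 1 in one place: 4-carboxyphenyl in place of 2-aminophenyl on a saturated chain carbon bound to an oxygen on an aromatic ring. Going by the values given here, no pair of measured compounds shows what such a change does to the number, so the expectation rests on compound 1 alone, with compound 2 as the only other reference point. The step from compound 1 to compound 3 is expected to be a 2.1-fold higher number from compound 1 to compound 3 (0.33 log units; beyond the scatter), towards a weaker inhibitor, though it could remain inside the scatter. For compound 3 the estimated value in this assay is 30000 nM, with a range from 10000 nM to 100000 nM.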

Compound 3, half-maximal inhibitory concentration: > 100000 nM
Compound 3: a limit, no number; the forecaster's own chance of this, stated with the estimate: 25%; middle value at least 3.3-fold (0.52 log units) away from the limit.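

The position on the saturated chain carbon bound to an oxygen on an aromatic ring is not indifferent to what it carries: placing 4-carboxyphenyl there in place of 2-aminophenyl gives an at least 7.1-fold higher number from compound 1 to compound 3 (0.85 log units; beyond the scatter). In this assay, going by these compounds, compound 3 gives > 100000 nM, which is a limit of the assay and not a number, so the true size of this loss remains unknown. This is the first step in the series to fall clearly beyond the scatter, and the reading sits at the assay's limit: the limit of > 100000 nM in this assay, at which 1 of the 3 values shown sits.

Because the whole aryl group changes in this step, it cannot separate the loss of the amine from the arrival of the carboxylic acid. A methyl ester or a primary amide in place of the carboxylic acid would help to separate them, and the compounds shown leave open how either would behave.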